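Swapping 4-Chlorophenyl for Cyclopropyl on the Ring Nitrogen

The source may report more compounds than this note shows. Statements on the series, on what has been measured and on what is new or still open speak of the compounds shown alone.

Values in a functional assay on MCF7 cells (Homo sapiens) for antiproliferative activity, read by MTT assay, with a stated time of 72 h; a higher number here means a weaker inhibitor, a lower number a stronger inhibitor:
- Compound 1 `O=C1COc2ccc(-c3cccc(NS(=O)(=O)c4ccc(F)cc4)c3)cc2N1`: 18300 nM
- Compound 2 `COc1cccc(N2C(=O)COc3ccc(-c4cccc(NS(=O)(=O)c5ccc(F)cc5)c4)cc32)c1`: > 40000 nM (a limit, not a number)
- Compound 3 `O=C1COc2ccc(-c3cccc(NS(=O)(=O)c4ccc(F)cc4)c3)cc2N1c1ccc(Cl)cc1`: 39800 nM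

Compound 3 has the higher of the two true numbers, with a 2.2-fold higher number from compound 1 to compound 3 (0.34 log units; beyond the scatter). Compound 4 `O=C1COc2ccc(-c3cccc(NS(=O)(=O)c4ccc(F)cc4)c3)cc2N1C1CC1` carries cyclopropyl in place of 4-chlorophenyl on an amide-type nitrogen in a ring. The hydrogen on that nitrogen has been replaced twice, giving an at least 2.1-fold higher number from compound 1 to compound 2 (0.33 log units; beyond the scatter) and a 2.2-fold higher number from compound 1 to compound 3 (0.34 log units; beyond the scatter), both modest or larger. With fewer heavy atoms than 4-chlorophenyl, cyclopropyl is expected to move the number partway back toward compound 1 in this assay. The estimated step is a 1.5-fold lower number from compound 3 to compound 4 (0.18 log units; within the scatter), a small drop. For compound 4 the expected value is 26000 nM, with an estimated range of 12000 nM to 40000 nM.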

Compound 4, half-maximal inhibitory concentration: > 40000 nM
Compound 4 was reported as a limit; the forecaster's own chance of this, stated with the estimate: 15%; middle value at least 1.5-fold (0.18 log units) from the limit.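

Cyclopropyl in place of hydrogen on the ring nitrogen gives an at least 2.1-fold higher number from compound 1 to compound 4 (0.33 log units; beyond the scatter) in this assay. The loss against compound 1 is therefore not confined to aromatic groups, since the non-aromatic cyclopropyl, with only 3 heavy atoms, also falls on the weaker side. For compound 4, > 40000 nM is a limit and not a number. Cyclopropyl in place of 4-chlorophenyl gives a number no lower from compound 3 to compound 4 (the limit leaves the size open). The step from compound 2 to compound 4 cannot be read: the limit of > 40000 nM in this assay, at which 2 of the 4 values shown sit.

On these data alone, whether methyl, or a longer chain ending in an amine or a carboxylic acid, on this nitrogen would keep the number close to that of compound 1 stays open.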